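Notes on the aryl hydrazone series: from compound 3 to compound 4

The source may hold more compounds than are shown below. What is called first, only, known or untested is meant among the compounds shown, and "the series" means these compounds.

Measured so far:
compound 1, `CCCSc1nc(N/N=C(\C)c2ccccc2O)c2nnn(Cc3ccco3)c2n1`, in a functional assay on MGC-803 cells (Homo sapiens) for antiproliferative activity, read by MTT assay, with a stated time of 72 h (on this read-out lower numbers stand for stronger inhibition and higher numbers for weaker inhibition), gives 4760 nM.
compound 2, `CCCSc1nc(N/N=C/c2ccc(C)cc2)c2nnn(Cc3ccccc3)c2n1`, in this assay gives > 64000 nM, a limit of the assay.
compound 3, `CCCSc1nc(N/N=C/c2ccc([N+](=O)[O-])cc2)c2nnn(Cc3ccccc3)c2n1`, in this assay gives 10100 nM.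

Compound 3 holds the highest of the two numbers; compound 1 sits below it, beyond the scatter, and compound 2 is known only as a limit (the limit of > 64000 nM in this assay, at which 1 of the 3 values shown sits). Compound 4, `CCCSc1nc(N/N=C/c2ccccc2)c2nnn(Cc3ccccc3)c2n1`, differs from compound 3 by hydrogen in place of nitro on an aromatic carbon. Among the compounds with values here, the one step that bears on this is an at least 6.3-fold lower number from compound 2 to compound 3 (0.80 log units; beyond the scatter), which shows the nitro group lowering the number. Taking the nitro away is therefore expected to raise the number, by about a 3.0-fold higher number from compound 3 to compound 4 (0.47 log units; beyond the scatter). Compound 4 is estimated at 30000 nM, between 9000 nM and 64000 nM.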

Compound 4, half-maximal inhibitory concentration: > 64000 nM
Compound 4 ended at the assay's limit (the forecaster's own chance of this, stated with the estimate: 30%); at least 2.1-fold (0.32 log units) between middle value and limit.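

Hydrogen in place of nitro gives an at least 6.3-fold higher number from compound 3 to compound 4 (0.80 log units; beyond the scatter). Within the data shown here, the earlier step could be read as nitro against methyl alone; with the unsubstituted phenyl also at the limit, compound 3 is the only one of compounds 2, 3 and 4 to give a number. The step from compound 2 to compound 4 cannot be read, and methyl and hydrogen stay unranked: the limit of > 64000 nM in this assay, at which 2 of the 4 values shown sit.

Still open, as far as these compounds go, is whether another group on this aromatic carbon, such as an amine or a carboxylic acid, would give a number as the nitro group does.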